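This account rests on a few compounds, and the source may have more. Where it says the series, first, only, none or still open, it means among the compounds named here.

Compound 1 `O=C(Nc1ccc(S(F)(F)(F)(F)F)cc1)c1ccc(Sc2ccc(O)cc2)cc1` and compound 2 `O=C(Nc1ccc(C(F)(F)F)cc1)c1ccc(Sc2ccc(O)cc2)cc1` share one core, and compound 3 `O=C(Nc1cccc(S(F)(F)(F)(F)F)c1)c1ccc(S(=O)(=O)c2ccc(O)cc2)cc1` and compound 4 `O=C(Nc1cccc(C(F)(F)F)c1)c1ccc(S(=O)(=O)c2ccc(O)cc2)cc1` share another; the difference between the two cores is not broken down here. In a functional assay on DU-145 cells (Homo sapiens) for antiproliferative activity, read by fluorescence and propidium iodide staining, with a stated time of 96 h (a lower number here means a stronger inhibitor, a higher number a weaker inhibitor), compound 1 gives 6760 nM and compound 2 gives 8550 nM, while compound 3 gives 6010 nM. All three numbers lie within the usual scatter of one another, so no order among them can be claimed.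

The change from compound 1 to compound 2 is a group of 4 heavy atoms (1 carbon, 3 fluorine; no ring) in place of a group of 6 heavy atoms (5 fluorine, 1 sulfur; no ring), on an aromatic carbon, and it made a step of a 1.3-fold higher number from compound 1 to compound 2 (0.10 log units; within the scatter). The change from compound 3 to compound 4 is a group of 4 heavy atoms (1 carbon, 3 fluorine; no ring) in place of a group of 6 heavy atoms (5 fluorine, 1 sulfur; no ring), on an aromatic carbon. It is the same kind of change, but not the same: in the first pair the group sits para to a large group, in the second pair meta to a large group.

Within the data shown here, for compound 4 in this assay a step of a 1.2-fold higher number from compound 3 to compound 4 (0.10 log units; within the scatter) is expected, beside the earlier step, because the only guide is a 1.3-fold higher number from compound 1 to compound 2 (0.10 log units; within the scatter) and it lies within the scatter. Compound 4 is therefore estimated at 7500 nM, with a likely range from 3800 nM to 15000 nM.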

Compound 4, half-maximal inhibitory concentration: 17700 nM
For compound 4 the middle estimate is 2.4-fold (0.37 log units) below the measured one; measured number above the stated range.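

In this assay, putting trifluoromethyl in place of the sulfur group with its five fluorines gave a 2.9-fold higher number from compound 3 to compound 4 (0.47 log units; beyond the scatter), a modest weakening on the core of compound 3. Set beside the same change on the core of compound 1, this larger step cannot be said to differ from the earlier one: the same change on two cores in this assay, a 1.3-fold higher number (0.10 log units; within the scatter) from compound 1 to compound 2 and a 2.9-fold higher number (0.47 log units; beyond the scatter) from compound 3 to compound 4, 2.3-fold (0.37 log units) apart, within the scatter of two such steps Only the second pair shows a step beyond the scatter, so these two pairs neither establish that the change carries over with one size nor show that its size depends on the core, and the group also sits differently in the two pairs, which would blur any such reading.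

The compounds shown leave open how a chlorine, a methyl group or a nitrile would read in that place in this assay. They also leave open whether an amine or a carboxylic acid in place of the hydroxyl group would change these numbers.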